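Swapping the amide partner of compound 1 for a difluoropiperidine

The source may report more compounds than this note shows. Statements on the series, on what has been measured and on what is new or still open speak of the compounds shown alone.

Compound 1 `CCN(CC)S(=O)(=O)c1ccc(S(=O)(=O)N2CCC[C@@H](C(=O)N[C@H]3CC[C@H](OC)CC3)C2)cc1` is the weakest of the three compounds measured in a functional assay on MIA PaCa-2 cells (Homo sapiens) for inhibition, read by MTT assay, with a stated time of 3 days; a lower number here means a stronger inhibitor, a higher number a weaker inhibitor: compound 1 gives 2290 nM. Its closest neighbour is compound 3 `CCN(CC)S(=O)(=O)c1ccc(S(=O)(=O)N2CCC[C@@H](C(=O)N[C@H]3CC[C@@H](OC)CC3)C2)cc1`, for which 590 nM is recorded, and the step of a 3.9-fold lower number from compound 1 to compound 3 (0.59 log units; beyond the scatter) rests only on (the fact that compounds 1 and 3 differ only in the configuration as drawn). Far away stands compound 2 `O=C([C@@H]1CCCN(S(=O)(=O)c2ccc(S(=O)(=O)C3CCC3)cc2)C1)N1CCC(F)(F)CC1` with 12.6 nM; compound 2 shares the 4,4-difluoropiperidin-1-yl amide but carries a different aryl sulfone, so no single step links it to compound 1.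

Compound 4 `CCN(CC)S(=O)(=O)c1ccc(S(=O)(=O)N2CCC[C@@H](C(=O)N3CCC(F)(F)CC3)C2)cc1` keeps everything of compound 1 except the amide partner: 4,4-difluoropiperidin-1-yl in place of (4-methoxycyclohexyl)amino on a carbonyl carbon. For the measured compounds named here, no measured step repeats this exact change. Going by the values given here, the step from compound 1 to compound 3 shows that the amide region of this core is sensitive, and compound 2, the only compound bearing the entering group, sits at 12.6 nM. On that basis compound 4 is expected to improve markedly, the estimated step being a 19-fold lower number from compound 1 to compound 4 (1.28 log units; beyond the scatter), while the remaining difference in the sulfone between compound 2 and compound 4 leaves the size uncertain. Compound 4 is therefore estimated at 120 nM, within a range from 25 nM to 600 nM.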

Compound 4, half-maximal inhibitory concentration: 19 nM
Compound 4: the middle estimate sits 6.3-fold (0.80 log units) above what was measured, outside the stated range (below it).
By their numbers in this assay, from the lowest: compounds 2 and 4 (each within the scatter of the next); then compound 3; then compound 1.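

In this assay, putting 4,4-difluoropiperidin-1-yl in place of (4-methoxycyclohexyl)amino on a carbonyl carbon gives a 120-fold lower number from compound 1 to compound 4 (2.08 log units; beyond the scatter), and the same exchange gives a 31-fold lower number from compound 3 to compound 4 (1.49 log units; beyond the scatter), both large steps. The exchange can thus be read from two starting points, so the gain does not rest on one drawn form of the group that leaves: the fact that compounds 1 and 3 differ only in the configuration as drawn. With the entering amide in place, diethylamino in place of cyclobutyl on a sulfonyl sulfur gives a 1.5-fold higher number from compound 2 to compound 4 (0.18 log units; within the scatter), which lies within the scatter, so the two sulfonyl groups cannot be told apart in this pair.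

What the compounds shown leave open is whether the gain follows the fluorine atoms, the six-membered ring with its nitrogen, or the loss of the amide hydrogen, a question that a plain piperidin-1-yl amide or a morpholin-4-yl amide would bear on. Going by these compounds, it also remains open whether the sulfonyl sulfur tolerates other groups as well, such as a phenyl ring or a morpholin-4-yl group, alongside the 4,4-difluoropiperidin-1-yl amide.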